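The source may report more compounds than this note shows. Statements on the series, on what has been measured and on what is new or still open speak of the compounds shown alone.

Measured so far in a physicochemical assay for solubility, using the shake flask method, in simulated intestinal fluid, measured as kinetic solubility, with a stated time of 2 h, at 25 degrees C, at pH 6.5; a lower number here means a less soluble compound, a higher number a more soluble compound:

compound 1 `COC(=O)c1nc(C)c2c(c1N)C(=O)N(Cc1ccccc1)C2=O` gives 7400 nM.
compound 2 `Cc1noc(-c2nc(C)c3c(c2N)C(=O)N(Cc2ccc(-c4ccncc4)cc2)C3=O)n1` gives < 5000 nM, which is a limit of the assay.
compound 3 `Cc1noc(-c2nc(C)c3c(c2N)C(=O)N(Cc2ccc(Cl)cn2)C3=O)n1` gives < 5000 nM, which is likewise a limit of the assay.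

Compound 2 therefore does not stand on a measured number in this assay but on a limit, and the same is true of compound 3; only compound 1 has a numerical result. That is what the limit of < 5000 nM in this assay, at which 2 of the 3 values shown sit, describes. For the measured compounds named here, no two of the measured compounds differ from each other in a single place, so no measured step is available to lean on.

Compound 4 `Cc1noc(-c2nc(C)c3c(c2N)C(=O)N(Cc2ccc(SC(F)(F)F)cc2)C3=O)n1` has not yet been measured. It is derived from compound 2 by a change in one place: (trifluoromethyl)sulfanyl in place of pyridin-4-yl on an aromatic carbon.

Since compound 2 already sits at the limit, there is no room for compound 4 to show a smaller value that could be told apart from it. I expect compound 4 to remain at or under that limit, so the step that the limit leaves unreadable from compound 2 to compound 4 is expected to be none beyond the usual scatter, and the assay may well again return only a limit. My estimate for compound 4 in this assay is 2000 nM, with a likely range from 400 nM to 6000 nM.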

Compound 4, solubility: < 5000 nM
Compound 4: a limit, no number (the forecaster's own chance of this, stated with the estimate: 85%); the middle value is on the limit's open side.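

In this assay, compound 4 gives < 5000 nM, which is a limit of the assay and not a number. For the compounds shown here, compound 2 also stands at a limit, so no step from compound 2 to compound 4 can be read, and the result marks only this: the limit of < 5000 nM in this assay, at which 3 of the 4 values shown sit. As far as these compounds go, how (trifluoromethyl)sulfanyl in place of pyridin-4-yl affects solubility therefore stays open.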